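Swapping an N-methyl anilino for a pyridinylamino on the core

The compounds below may be only part of what the source reports. "The series", "measured", "known", "first", "only" and "open" are said of these compounds alone.

The two measured compounds share one core. Compound 1 `Cn1ccc2cc(-c3ccc4oc(Nc5ccccc5)nc4c3)ccc21` gives 48 nM in an assay on HEK293 cells for inhibition of Fatty-acid amide hydrolase 1 (Homo sapiens), read by fluorescence; on this read-out lower numbers stand for stronger inhibition and higher numbers for weaker inhibition. Among the compounds with values here, compound 2 `CN(c1ccccc1)c1nc2cc(-c3ccc4c(ccn4C)c3)ccc2o1` gives 68 nM in this assay; the only step measured between them, a 1.4-fold higher number from compound 1 to compound 2 (0.15 log units; within the scatter), is a methyl in place of hydrogen on a nitrogen on an aromatic ring. Compound 2 therefore stands at the higher of the two numbers, yet its gap to compound 1 is within the scatter, so no order between them can be claimed.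

Compound 3 `Cn1ccc2cc(-c3ccc4oc(Nc5cccnc5)nc4c3)ccc21` is not yet measured. It differs from compound 2 by (pyridin-3-yl)amino in place of methyl(phenyl)amino on an aromatic carbon. Within the data shown here, only the step from compound 1 to compound 2 bears on this change, and only in part, since it concerns the methyl on the nitrogen and not the ring exchanged for a pyridine. That step was within the scatter, and nothing measured here speaks to the ring exchange, so the expected step in this assay is a 1.5-fold lower number from compound 2 to compound 3 (0.18 log units; within the scatter), with no direction beyond the scatter. Compound 3 is thus estimated at 45 nM, within a range of 15 nM to 150 nM.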

Compound 3, half-maximal inhibitory concentration: 226 nM
Compound 3: the middle estimate sits 5.0-fold (0.70 log units) below what was measured; measured number outside the range, above it.
By their numbers in this assay, from the lowest: compounds 1 and 2 (each within the scatter of the next); then compound 3.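

With the amino hydrogen kept, pyridin-3-yl in place of phenyl on the nitrogen gives a 4.7-fold higher number from compound 1 to compound 3 (0.67 log units; beyond the scatter) in this assay, so exchanging the ring matters here in a way that adding the methyl on that nitrogen did not. The full exchange of methyl(phenyl)amino for (pyridin-3-yl)amino on the aromatic carbon gives a 3.3-fold higher number from compound 2 to compound 3 (0.52 log units; beyond the scatter), also beyond the scatter. Among these three compounds, the phenyl on the amino nitrogen accepts the methyl without a readable shift, while the pyridin-3-yl ring sets compound 3 apart from compound 1 and compound 2.

No evidence here gives a reason for this shift. Still open, as far as these compounds go, is whether pyridin-2-yl or pyridin-4-yl would behave like pyridin-3-yl, whether a fluorine or methoxy on the phenyl would shift the number, and what a methyl on the nitrogen of the (pyridin-3-yl)amino would do.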